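The source may report more compounds than this note shows. Statements on the series, on what has been measured and on what is new or still open speak of the compounds shown alone.

In a functional assay on a cell-free system (plasma, Oryctolagus cuniculus) for inhibition, with stated times of 5 min, 1 min and 6 min (a higher number here means a weaker inhibitor, a lower number a stronger inhibitor), compound 1 (`CCOC(=O)c1c(C)nc(-c2cccc(C#N)c2)n1OC`) gives 9130 nM and compound 2 (`CCOC(=O)c1c(C)nc(-c2cccc(C#N)c2)n1OCc1cccc(F)c1`) gives 22400 nM, the higher of the two numbers, which makes compound 2 the weaker inhibitor of the pair. Compound 3 (`CCOC(=O)c1c(C)nc(-c2cccc(C#N)c2)n1OCc1ccc(Br)cc1`) differs from compound 2 in one place: 4-bromophenyl in place of 3-fluorophenyl on a saturated chain carbon bound to an oxygen on an aromatic ring. Here 4-bromophenyl stands in place of 3-fluorophenyl on a saturated chain carbon bound to an oxygen on an aromatic ring. Within the data shown here, only one measured step bears on this: a 2.5-fold higher number from compound 1 to compound 2 (0.39 log units; beyond the scatter), where 3-fluorophenyl replaced hydrogen. Among the measured compounds shown here, no measured pair shows one substituted phenyl exchanged for another, so that modest step offers only a loose guide. No shift beyond the scatter is therefore expected in this assay, with the direction left open. The expected change is a 1.1-fold lower number from compound 2 to compound 3 (0.05 log units; within the scatter). Compound 3 is estimated at 20000 nM, with an expected range of 8000 nM to 50000 nM.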

Compound 3, half-maximal inhibitory concentration: 24600 nM
Compound 3: middle estimate off by 1.2-fold (0.09 log units), on the low side; the measured number falls inside the stated range.
By their numbers in this assay, from the lowest: compound 1; then compounds 2 and 3 (each within the scatter of the next).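

In this assay, among these compounds, 4-bromophenyl in place of 3-fluorophenyl on a saturated chain carbon bound to an oxygen on an aromatic ring gives a 1.1-fold higher number from compound 2 to compound 3 (0.04 log units; within the scatter) and thus provides the first exchange of one substituted phenyl for another, with no shift beyond the scatter. Against hydrogen at the same carbon, 4-bromophenyl gives a 2.7-fold higher number from compound 1 to compound 3 (0.43 log units; beyond the scatter) and so follows 3-fluorophenyl in direction, leaving both substituted phenyl groups on the weaker side of compound 1. No measurement shown accounts for the two phenyl groups reading alike or for their difference from hydrogen.

On these data alone, whether an unsubstituted phenyl, a phenyl carrying an amine or a carboxylic acid, or a longer chain would read the same remains open. So does whether any group at this place could give a lower number than compound 1 at 9130 nM.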